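Hydroxypyrrolidine Replaces the Aldehyde on the Benzyl Ether

A few compounds are considered here, and "the series" means these few. Any claim that something is new, unique, unknown or untested is made for them only; others in the source may bear on it.

Compound 1, `COc1ccc(/C=C\c2cc(OC)c(OC)c(OC)c2)cc1OCc1ccc(C=O)cc1`: 900 nM in a functional assay on MC-38 cells (Mus musculus) for antiproliferative activity, read by CCK-8 assay, with a stated time of 48 h; a lower number here means a stronger inhibitor, a higher number a weaker inhibitor.
Compound 2, `COc1ccc(/C=C\c2cc(OC)c(OC)c(OC)c2)cc1OCc1ccc(CN2CC(C(=O)O)C2)cc1`: > 10000 nM, which is a limit of this assay rather than a number.
Compound 3, `COc1ccc(/C=C\c2cc(OC)c(OC)c(OC)c2)cc1OCc1ccc(CN2CC[C@@H](C(=O)O)C2)cc1`: 6300 nM.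

Among the numbers shown, compound 1 stands lowest; its nearest neighbour is compound 3, reached by a 7.0-fold higher number from compound 1 to compound 3 (0.85 log units; beyond the scatter). The move to compound 2 was larger, an at least 11-fold higher number from compound 1 to compound 2 (1.04 log units; beyond the scatter), and compound 2 sits at the limit of > 10000 nM in this assay, at which 1 of the 3 values shown sits. Between the two acids, an at least 1.5-fold lower number from compound 2 to compound 3 (0.20 log units; that floor lies within the scatter).

Compound 4, `COc1ccc(/C=C\c2cc(OC)c(OC)c(OC)c2)cc1OCc1ccc(CN2CC[C@@H](O)C2)cc1`, has not yet been measured in this assay. It differs from compound 1 in one place: (3-hydroxypyrrolidin-1-yl)methyl in place of formyl on an aromatic carbon. Both measured steps away from compound 1 bear on it, since each likewise exchanges the formyl for a chain carrying a saturated nitrogen ring on the same aromatic carbon, and the step to compound 3, with its five-membered ring, is the closer analogue. Both steps weakened the compound, one modestly and one at least largely. Compound 4 is therefore expected to give a higher number than compound 1, with an expected step of a 3.3-fold higher number from compound 1 to compound 4 (0.52 log units; beyond the scatter). The estimate for compound 4 in this assay is 3000 nM, expected to fall between 1000 nM and 9000 nM.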

Compound 4, half-maximal inhibitory concentration: 6900 nM
Compound 4: middle estimate off by 2.3-fold (0.36 log units), on the low side, and the stated range covers the measured number.
By their numbers in this assay, from the lowest: compound 1; then compounds 3 and 4 (each within the scatter of the next). At a limit, above all of these: compound 2.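

In this assay, the (3-hydroxypyrrolidin-1-yl)methyl group on this aromatic carbon lands well above the formyl compound, with a 7.7-fold higher number from compound 1 to compound 4 (0.88 log units; beyond the scatter), so this second substituent carrying a five-membered nitrogen ring also fails to hold the number of compound 1. Hydroxy in place of carboxy on a saturated ring carbon gives a 1.1-fold higher number from compound 3 to compound 4 (0.04 log units; within the scatter), so compound 3 and compound 4 stand within the scatter of each other, and among the compounds shown the loss against compound 1 appears with the carboxy group and with the hydroxy group alike. The remaining comparison gives only a floor, with an at least 1.4-fold lower number from compound 2 to compound 4 (0.16 log units; that floor lies within the scatter), and no order can be claimed from it. Compound 2 gives only a limit of the assay: the limit of > 10000 nM in this assay, at which 1 of the 4 values shown sits.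

From the compounds shown here alone, what remains open is which part of the new chain carries the loss, the ring nitrogen or the ring substituent, and a plain pyrrolidin-1-ylmethyl group or a simple hydroxymethyl group in place of the formyl would begin to separate them. Also open, going by these compounds, is whether the formyl group itself is what sets compound 1 apart, and whether the opposite configuration at the ring carbon, or a six-membered piperidine ring, would shift the number at all.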